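The source may hold more compounds than are shown below. What is called first, only, known or untested is meant among the compounds shown, and "the series" means these compounds.

Compound 3 `COc1cc(C(c2ccc(O)c(OC)c2)[C@H](C)[C@@H](C)CO)ccc1O` carries a 2-(hydroxymethyl)-1-methylpropyl group on a saturated chain carbon bound to two aromatic carbons. On these data alone, in a functional assay on HL-60 cells (Homo sapiens) for cytotoxicity, read by WST assay, with a stated time of 48 h (a higher number here means a weaker inhibitor, a lower number a stronger inhibitor), compound 3 gives only a limit, > 100000 nM, so its exact number is unknown. Compound 1 `COC[C@H](C(C)C)C(c1ccc(O)c(OC)c1)c1ccc(O)c(OC)c1` gives 72000 nM and compound 2 `COc1cc(C(c2ccc(O)c(OC)c2)[C@H](C)[C@@H](C)CF)ccc1O` gives 45000 nM in this assay. Compound 4 `COc1cc(C(c2ccc(O)c(OC)c2)[C@@H](C)[C@@H](C)CF)ccc1O` differs from compound 3 in one place: 2-(fluoromethyl)-1-methylpropyl in place of 2-(hydroxymethyl)-1-methylpropyl on a saturated chain carbon bound to two aromatic carbons. Among the measured compounds shown here, the one measured step bearing on this change runs the other way, hydroxy replacing fluoro, and was an at least 2.2-fold higher number from compound 2 to compound 3 (0.34 log units; beyond the scatter). Reversing it, a lower number is expected for compound 4, of about that size, an at least 2.0-fold lower number from compound 3 to compound 4 (0.30 log units; that floor lies within the scatter). Compound 2 carries the same entering group with its two defined stereocentres set differently, so the match is loose. Compound 4 is estimated at 50000 nM, likely between 20000 nM and 120000 nM.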

Compound 4, half-maximal inhibitory concentration: 38000 nM
The estimate for compound 4 lay 1.3-fold (0.12 log units) above the measured number; the measured number falls inside the stated range.
By their numbers in this assay, from the lowest: compounds 4, 2 and 1 (each within the scatter of the next). At a limit, above all of these: compound 3.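

In this assay, the fluoromethyl chain also gives a separation from the hydroxymethyl chain with the stereocentre drawn the other way: an at least 2.6-fold lower number from compound 3 to compound 4 (0.42 log units; beyond the scatter). The value of compound 3 is only a limit, so this step is a floor. Changing that stereocentre alone does not separate the two fluorinated compounds, a 1.2-fold lower number from compound 2 to compound 4 (0.07 log units; within the scatter), and the fluoromethyl chain is not separated from the methoxymethyl chain either, a 1.9-fold lower number from compound 1 to compound 4 (0.28 log units; within the scatter). On these data alone, the exact value of compound 3 remains unknown, and so does the effect of the other hydroxymethyl configuration. As far as these compounds go, whether an amine, a carboxylic acid or a longer chain here would give a lower number also stays open.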